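The source may report more compounds than this note shows. Statements on the series, on what has been measured and on what is new or still open speak of the compounds shown alone.

Measured in an ADME assay on H9c2 cells (Rattus norvegicus) for cytotoxicity, read by resazurin assay, with a stated time of 72 h; on this read-out higher numbers stand for lower toxicity in this test and lower numbers for higher toxicity in this test:
- Compound 1 `C/C(=N\Nc1nc(CCl)cs1)c1ccc(Cl)c(Cl)c1`: > 50000 nM (a limit of the assay, not a number)
- Compound 2 `C/C(=N\N=c1\scc(-c2ccccc2)n1-c1ccccc1)c1ccc(Cl)c(Cl)c1`: > 50000 nM (a limit of the assay, not a number)
- Compound 3 `C/C(=N\Nc1nc(-c2ccccn2)cs1)c1ccc(Cl)c(Cl)c1`: 10200 nM

Within the data shown here, compound 3 gives 10200 nM, the only true number in this small set. The other two results are limits: the limit of > 50000 nM in this assay, at which 2 of the 3 values shown sit.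

Moving on to compound 4 `C/C(=N\Nc1nc(-c2ccc(F)cc2)cs1)c1ccc(Cl)c(Cl)c1` makes a single change, 4-fluorophenyl in place of pyridin-2-yl on an aromatic carbon.

Among the measured compounds shown here, the one measured step that touches this place is an at least 4.9-fold lower number from compound 1 to compound 3 (0.69 log units; beyond the scatter), where pyridin-2-yl replaced chloromethyl. That step shows that the group here can shift the result in this assay. However, it involves a different exchange, so it offers only a rough guide to size and none to direction for the new group.

A small rise, within the usual scatter, is therefore expected, and the estimated step is a 1.5-fold higher number from compound 3 to compound 4 (0.17 log units; within the scatter). The range is kept wide on the upper side. For compound 4 the expected value is 15000 nM, with an estimated range of 5000 nM to 45000 nM.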

Compound 4, half-maximal cytotoxic concentration: > 50000 nM
Compound 4 was reported as a limit; the forecaster's own chance of this, stated with the estimate: 25%; at least 3.3-fold (0.52 log units) between middle value and limit.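

Placing 4-fluorophenyl instead of pyridin-2-yl on this aromatic carbon gives an at least 4.9-fold higher number from compound 3 to compound 4 (0.69 log units; beyond the scatter) in this assay, so the number at this position can rise as well as fall. Among the four compounds, only compound 3 gives a true number, and compounds 1, 2 and 4 all sit at the assay limit: the limit of > 50000 nM in this assay, at which 3 of the 4 values shown sit.

Compound 1 and compound 4 both stand at that limit, so the step between them cannot be read.

On these data alone, it remains open whether the rise follows the loss of the pyridine nitrogen or the arrival of the fluorine, and a plain phenyl on the same core would help separate the two. As far as these compounds go, how other groups at this position, such as pyridin-4-yl or aminomethyl, would read in this assay also remains open.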